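Amide Variation on a Shared Core Against Pancreatic Cancer Cells

The compounds below may be only part of what the source reports. "The series", "measured", "known", "first", "only" and "open" are said of these compounds alone.

Compound 1 `CCN(CC)S(=O)(=O)c1ccc(S(=O)(=O)N2CCC[C@@H](C(=O)NC3CCOCC3)C2)cc1` in a functional assay on MIA PaCa-2 cells (Homo sapiens) for inhibition, read by MTT assay, with a stated time of 3 days; a lower number here means a stronger inhibitor, a higher number a weaker inhibitor: > 10000 nM, a limit of the assay.
Compound 2 `CCN(CC)S(=O)(=O)c1ccc(S(=O)(=O)N2CCC[C@@H](C(=O)N3CCC(F)(F)CC3)C2)cc1` in this assay: > 10000 nM, a limit of the assay.

Compound 2 stands at the limit of this assay, and it shares that position with compound 1, since both values shown sit at the limit of > 10000 nM in this assay, at which 2 of the 2 values shown sit. Going by the values given here, the one measured step, a step that the two limits leave unreadable from compound 1 to compound 2, therefore cannot be read in size or direction.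

Compound 3 `CCN(CC)S(=O)(=O)c1ccc(S(=O)(=O)N2CCC[C@@H](C(=O)N3CC[C@@H](OC)C3)C2)cc1` has not yet been measured. It differs from compound 2 in one place: 3-methoxypyrrolidin-1-yl in place of 4,4-difluoropiperidin-1-yl on a carbonyl carbon. Among the compounds with values here, the only step bearing on this change is the unreadable one from compound 1 to compound 2, so no measured step gives a size or direction to carry over. What is known is that both measured compounds sit at the limit, and compound 3 keeps the shared core and the sulfonamide groups unchanged.

On that basis compound 3 is expected to sit at the limit as well, with an estimated value of 20000 nM within a range from 5000 nM to 80000 nM. The step that the limit leaves unreadable from compound 2 to compound 3 is thus estimated to be none beyond the scatter.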

Compound 3, half-maximal inhibitory concentration: > 10000 nM
Compound 3: only a limit was reported; the forecaster's own chance of this, stated with the estimate: 80%; the middle value lies beyond the limit too.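

In this assay compound 3 also gave only a limit of the assay, so its steps from compound 1 and compound 2 cannot be read in size or direction, and all three compounds stand at the same place: the limit of > 10000 nM in this assay, at which 3 of the 3 values shown sit.

The compounds shown leave open how far each lies beyond that limit, and whether any amide on the shared core would give a measurable value.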